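A few compounds are considered here, and "the series" means these few. Any claim that something is new, unique, unknown or untested is made for them only; others in the source may bear on it.

Measured so far:
compound 1 `COc1cc(-c2ncnn2-c2ccc(F)cc2)cc(OC)c1OC` — > 10000 nM
compound 2 `COc1cc(-n2ncnc2-c2ccc(OC(F)(F)F)cc2)cc(OC)c1OC` — > 10000 nM

In a functional assay on A549 cells (Homo sapiens) for antiproliferative activity, read by MTT assay, with a stated time of 72 h (a higher number here means a weaker inhibitor, a lower number a stronger inhibitor), compound 1 gives > 10000 nM, which is a limit of the assay and not a number. In this assay compound 2 gives > 10000 nM, again a limit of the assay. For the measured compounds named here, compound 2 therefore stands at the limit of > 10000 nM in this assay, at which 2 of the 2 values shown sit; nothing separates compound 1 from compound 2 within the range the assay can read, and no single-change step between measured compounds exists in this set.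

Compound 3 `COc1cc(-n2ncnc2-c2ccc(F)cc2)cc(OC)c1OC` differs from compound 2 by fluoro in place of trifluoromethoxy on an aromatic carbon. Since every measured value sits at the limit, neither size nor direction of the step in this assay can be fixed from the data, and compound 1, which also carries fluoro, adds no reading within range. Compound 3 is expected to stay at the limit as well, estimated at 15000 nM with a range of 5000 nM to 50000 nM. The expected step that the limit leaves unreadable from compound 2 to compound 3 is thus nothing beyond the scatter.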

Compound 3, half-maximal inhibitory concentration: > 10000 nM
Compound 3: no number, only a limit; the forecaster's own chance of this, stated with the estimate: 80%; the middle value does not contradict the limit.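

In this assay compound 3 gives > 10000 nM, which is a limit of the assay and not a number. No step can be read from compound 2 to compound 3. The compounds shown leave open which structural change, if any, would bring a reading within the range of the assay: the limit of > 10000 nM in this assay, at which 3 of the 3 values shown sit.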